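The compounds below may be only part of what the source reports. "The series", "measured", "known", "first", "only" and "open" are said of these compounds alone.

In a functional assay on NCI-H1299 cells (Homo sapiens) for inhibition, read by CCK-8 assay, with a stated time of 72 h, tested at 10 uM (on this read-out lower numbers stand for a weaker effect and higher numbers for a stronger effect at the one concentration tested), two compounds of one shared core have been measured. Compound 1 `CN(C)C(=O)c1cc2cnc(Nc3ccc(S(=O)(=O)NCCCN=C=S)cc3)nc2n1C1CCCC1` gives 72.8%, the lower of the two numbers. Compound 2 `CN(C)C(=O)c1cc2cnc(Nc3ccc(C(=O)NCCCCCN=C=S)cc3F)nc2n1C1CCCC1` gives 86.7%, a gap beyond the usual scatter. Compound 3 `CN(C)C(=O)c1cc2cnc(Nc3ccc(NC(=O)CCCCN=C=S)cc3)nc2n1C1CCCC1` has not yet been measured; it differs from compound 1 in this way: a group of 10 heavy atoms (6 carbon, 2 nitrogen, 1 oxygen, 1 sulfur; no ring) in place of a group of 10 heavy atoms (4 carbon, 2 nitrogen, 2 oxygen, 2 sulfur; no ring), on an aromatic carbon. Among the compounds with values here, no measured pair shows this exact change, so the step it brings is uncertain. A small rise is expected, partly because compound 2 gives 86.7%. The expected step is a number 5.2 percentage points higher from compound 1 to compound 3 (within the scatter), a modest gain that may stay within the scatter. Compound 3 is estimated at 78%, between 62% and 90%.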

Compound 3, a percentage reported as inhibition, at one concentration (the size of the read-out at that concentration, not a potency): 82.5%
The estimate for compound 3 lay 4.5 percentage points below the measured number; the range from low to high includes it.
By their numbers in this assay, from the lowest: compounds 1, 3 and 2 (each within the scatter of the next, the first and the last beyond it).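

In this assay, placing the group of 6 carbon, 2 nitrogen, 1 oxygen and 1 sulfur atoms on the aromatic carbon, in place of the group of 4 carbon, 2 nitrogen, 2 oxygen and 2 sulfur atoms, gives a number 9.7 percentage points higher from compound 1 to compound 3 (within the scatter). This position therefore accepts a quite different group of the same heavy-atom count, with no difference that stands clear of the scatter. Nothing available here explains this result. From the compounds shown here alone, whether the position also accepts a chain ending in an amine or a carboxylic acid, rather than an isothiocyanate, remains open.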